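Replacing Dimethylamino with Piperidinyl on the Amide Aryl Ring

A few compounds are considered here, and "the series" means these few. Any claim that something is new, unique, unknown or untested is made for them only; others in the source may bear on it.

Of the compounds shown here, three built on one shared amide core have been measured in an assay on HeLa cells for agonist activity at Bile acid receptor (Homo sapiens), read by a luciferase reporter, with a stated time of 24 h; on this read-out lower numbers stand for an effect already at smaller amounts and higher numbers for an effect only at larger amounts of compound. Compound 1 `CC(C)(C)c1ccc(C(=O)NCc2ccc(N)cc2Cl)cc1` gives 40 nM. Going by the values given here, compound 2 `CCS(=O)(=O)Nc1ccc(CNC(=O)c2ccc(C(C)(C)C)cc2)c(Cl)c1` gives 500 nM, and the change between these two, a 13-fold higher number from compound 1 to compound 2 (1.10 log units; beyond the scatter), is the only one-place step within the measured set. Compound 3 `CN(C)c1ccc(C(=O)NCc2ccc(NS(C)(=O)=O)cc2Cl)cc1` gives 1460 nM, the highest number of the three; compound 2 stands nearest to it and compound 1 furthest, and both of those gaps lie beyond the scatter. Compound 3 and compound 2 differ in two places at once, so their two values show only that the pairing of dimethylamino with methylsulfonyl reads higher than the pairing of tert-butyl with ethylsulfonyl.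

Compound 4 `CS(=O)(=O)Nc1ccc(CNC(=O)c2ccc(N3CCCCC3)cc2)c(Cl)c1` differs from compound 3 in one place: piperidin-1-yl in place of dimethylamino on an aromatic carbon. Among the compounds with values here, no measured step touches this position. Within the data shown here, the single step that has been measured, a 13-fold higher number from compound 1 to compound 2 (1.10 log units; beyond the scatter), concerns a nitrogen on the other aromatic ring and offers no guide here, so there is no basis for expecting a large move in either direction in this assay. The step this estimate means, a 1.6-fold lower number from compound 3 to compound 4 (0.21 log units; within the scatter), is expected to stay small, within or only just beyond the scatter. For compound 4 the estimated value is 900 nM, with a range from 250 nM to 3000 nM.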

Compound 4, half-maximal effective concentration: 410 nM
Beside the measured number, compound 4's estimate is 2.2-fold (0.34 log units) above it; the measured number falls inside the stated range.
By their numbers in this assay, from the lowest: compound 1; then compounds 4 and 2 (each within the scatter of the next); then compound 3.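

In this assay, going by these compounds alone, the aromatic carbon that carries dimethylamino in compound 3 now has a measured step of its own, which no earlier pair could give: a 3.6-fold lower number from compound 3 to compound 4 (0.55 log units; beyond the scatter). So this position does respond to a change of group, and exchanging the open dimethylamino for piperidin-1-yl, with its six-membered non-aromatic ring and larger count of heavy atoms, moves the number down rather than up, while the hydrogen-bond donor and acceptor counts and the absence of net charge stay the same on both sides of the step. No measurement to hand accounts for this step, so the reason for it stays unknown.

The compounds shown cannot separate the contribution of the ring from that of the added carbon atoms, a question that groups such as diethylamino, pyrrolidin-1-yl or morpholin-4-yl would bear on. They also leave open whether the same exchange gives a step of similar size when the methylsulfonyl on the nitrogen of the other aromatic ring gives way to ethylsulfonyl or to the free amine.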